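A few compounds are considered here, and "the series" means these few. Any claim that something is new, unique, unknown or untested is made for them only; others in the source may bear on it.

In a functional assay on A2780 cells (Homo sapiens) for inhibition, with a stated time of 72 h (a higher number here means a weaker inhibitor, a lower number a stronger inhibitor), compound 1 `CC1(C)CCNc2ccc(NC(=S)Nc3ccc([N+](=O)[O-])cc3)cc21` gives 7100 nM and compound 2 `CN1c2ccc(NC(=O)Nc3ccc([N+](=O)[O-])cc3)cc2C(C)(C)C(O)C1(C)C` gives 8400 nM within the scatter of compound 1, so the two cannot be told apart. Compound 3 `CN1c2ccc(NC(=O)Nc3ccc(C(F)(F)F)cc3)cc2C(C)(C)C(O)C1(C)C` differs from compound 2 in one place: it has trifluoromethyl in place of nitro on an aromatic carbon, para to a large group (trifluoromethyl in place of nitro on an aromatic carbon). Among the compounds with values here, no measured pair shows this change, so no step beyond the scatter is expected in this assay in either direction. The expected step is small (a 1.4-fold lower number from compound 2 to compound 3 (0.15 log units; within the scatter)). Compound 3 is estimated at 6000 nM with an expected range from 2000 nM to 18000 nM as its bounds.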

Compound 3, half-maximal inhibitory concentration: 6700 nM
For compound 3 the middle estimate is 1.1-fold (0.05 log units) below the measured one; the range from low to high includes it.
By their numbers in this assay, from the lowest: compounds 3, 1 and 2 (each within the scatter of the next).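

Within the data shown here, the step (a 1.3-fold lower number from compound 2 to compound 3 (0.10 log units; within the scatter)) in this assay gives the first comparison of compounds differing in one place. On this aromatic carbon, para to a large group, trifluoromethyl and nitro cannot be told apart, so on the core of compound 2 the nitro group can be exchanged without a step beyond the scatter. No available evidence bears on this result. The compounds shown leave open whether an amine, a carboxylic acid or a longer chain at this place would behave the same way. They also leave open whether the same exchange holds on the core of compound 1.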